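A few compounds are considered here, and "the series" means these few. Any claim that something is new, unique, unknown or untested is made for them only; others in the source may bear on it.

Among the compounds with values here, only two compounds built on this shared core have numbers so far in a functional assay on T47D cells (Homo sapiens) for cytotoxicity, read by CCK-8 assay and cell counting, with stated times of 4 h and 2 days; on this read-out higher numbers stand for weaker inhibition and lower numbers for stronger inhibition. In that assay compound 1 `Oc1cccc(-c2cc(-c3ccccc3Cl)cc(-c3ccccc3)n2)c1` gives 680 nM and compound 2 `Oc1cccc(-c2cc(-c3ccc(Cl)cc3)cc(-c3ccco3)n2)c1` gives 680 nM, so compound 2 stands level with compound 1 at the digits shown. These two differ in more than one place, so their pair cannot reveal the effect of any single change.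

The next structure is compound 3 `Oc1cccc(-c2cc(-c3ccc(Cl)cc3)cc(-c3ccccc3)n2)c1`. It keeps the 3-hydroxyphenyl and 4-chlorophenyl groups of compound 2 but has phenyl in place of furan-2-yl on an aromatic carbon, next to the ring nitrogen: phenyl in place of furan-2-yl on an aromatic carbon. Within the data shown here, no measured pair isolates this swap, so any expectation is indirect. Compound 3 shares phenyl with compound 1, which gives 680 nM, the same number as compound 2 with its furan-2-yl. On that basis, no step beyond the scatter is expected in this assay, in either direction. The expected change is a 1.0-fold lower number from compound 2 to compound 3 (0.02 log units; within the scatter), an estimate that stays within the usual scatter. The estimate for compound 3 is 650 nM, with an expected range from 250 nM to 1700 nM.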

Compound 3, half-maximal inhibitory concentration: 680 nM
Beside the measured number, compound 3's estimate is 1.0-fold (0.02 log units) below it, within the range that was stated.
By their numbers in this assay, from the lowest: compounds 1, 2 and 3 (each within the scatter of the next).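

Within the data shown here, until now, no pair of compounds isolated a single change. Compound 3 supplies two such pairs. At the aromatic carbon next to the ring nitrogen, phenyl in place of furan-2-yl gives no change at the digits printed from compound 2 to compound 3 (within the scatter) in this assay, so exchanging this five-membered ring and its oxygen for a six-membered ring of carbon only leaves the number where it was. Compound 3 also isolates the place of the chlorine on the chlorophenyl group, as 4-chlorophenyl in place of 2-chlorophenyl gives no change at the digits printed from compound 1 to compound 3 (within the scatter), so these two arrangements also cannot be told apart here. No supporting measurement offers an explanation for either result.

From the compounds shown here alone, both steps concern only closely related aromatic groups, so it remains open whether the number would hold with an amine or a longer alkyl chain in place of phenyl at the carbon next to the ring nitrogen. The 3-hydroxyphenyl group is also the same throughout, which leaves open what a methoxy group in place of its hydroxyl would do in this assay.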